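Compound 4 Replaces Carbamoyl With Trifluoromethoxy

The source may hold more compounds than are shown below. What is called first, only, known or untested is meant among the compounds shown, and "the series" means these compounds.

Compounds measured in an ADME assay on HEK293 cells (Homo sapiens) for cytotoxicity, with a stated time of 72 h; a lower number here means that less compound is needed, a higher number that more compound is needed for the effect:
Compound 1 (`Cc1cc(NC(=O)Nc2ccccc2N)c2ccccc2n1`): > 25000 nM
Compound 2 (`Cc1cc(NC(=O)Nc2cccc(C(N)=O)c2)c2ccccc2n1`): > 25000 nM
Compound 3 (`COc1ccc(NC(=O)Nc2cc(C)nc3ccccc23)cc1OC`): > 25000 nM

Compound 2 stands at > 25000 nM in this assay, and this is a limit of the assay and not a number. It has no rank among the measured compounds, since the data show only (the limit of > 25000 nM in this assay, at which 3 of the 3 values shown sit). Compound 4 (`Cc1cc(NC(=O)Nc2cccc(OC(F)(F)F)c2)c2ccccc2n1`) carries trifluoromethoxy in place of carbamoyl on an aromatic carbon, meta to a large group, and the counted difference is trifluoromethoxy in place of carbamoyl on an aromatic carbon.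

Among the compounds with values here, no step between measured compounds is available, so the data do not show what a single change does in this assay. The three measured compounds differ in their substituents, yet none of them gives a number. The expectation is therefore for no step beyond the scatter, with any move more likely toward less compound being needed. The estimated change is an at least 1.2-fold lower number from compound 2 to compound 4 (0.09 log units; that floor lies within the scatter) in this reading. Compound 4 may well return only a limit again. For compound 4 the expected value is 20000 nM, with an estimated range from 7000 nM to 40000 nM for the measurement.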

Compound 4, half-maximal effective concentration: 22000 nM
For compound 4 the middle estimate is 1.1-fold (0.04 log units) below the measured one; the measured number falls inside the stated range.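

In this assay compound 4 gives 22000 nM, the only number among the compounds shown: with trifluoromethoxy on this aromatic carbon, meta to a large group, the assay returns a value, where carbamoyl at the same place returned none. Compound 2 gives > 25000 nM, which is a limit of the assay and not a number. The change therefore reads only as an at least 1.1-fold lower number from compound 2 to compound 4 (0.05 log units; that floor lies within the scatter), a floor and not a measured size, so this first readable step shows that the swap can be given a direction at most tentatively and cannot be told apart from the scatter.

The true size of the step remains open, and with so few numbers in hand the compounds shown cannot rank the substituents against one another, because most of the series gives no value: the limit of > 25000 nM in this assay, at which 3 of the 4 values shown sit. Whether a carboxylic acid or a nitrile at the same place would return a number or yet another limit is something these compounds do not tell.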